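This account rests on a few compounds, and the source may have more. Where it says the series, first, only, none or still open, it means among the compounds named here.

Going by the values given here, in a functional assay on QGY-7703 cells (Homo sapiens) for cytotoxicity, read by MTT assay, with a stated time of 24 h (a lower number here means a stronger inhibitor, a higher number a weaker inhibitor), compound 1 `CN1C/C(=C\c2ccncc2)C(=O)/C(=C/c2ccccc2F)C1` gives 4900 nM and compound 2 `O=C1/C(=C/c2ccncc2)CN(S(=O)(=O)c2ccc(Cl)cc2)C/C1=C\c1ccccc1F` gives 12500 nM, so compound 2 holds the higher of the two numbers so far. Compound 3 `O=C1/C(=C/c2ccncc2)CN(S(=O)(=O)c2ccc(Br)cc2)C/C1=C\c1ccccc1F` departs from compound 2 at a single place: bromo in place of chloro on an aromatic carbon. This puts bromo in place of chloro on an aromatic carbon, para to a large group, and leaves the rest of the structure unchanged. Among the compounds with values here, the one measured step, a 2.6-fold higher number from compound 1 to compound 2 (0.41 log units; beyond the scatter), comes from exchanging methyl for (4-chlorophenyl)sulfonyl on the ring amine nitrogen. Within the data shown here, that exchange is much larger than the swap of one halogen for another, and no measured step tests the swap itself. No step beyond the scatter is therefore expected in this assay. The estimate is a 1.0-fold lower number from compound 2 to compound 3 (0.02 log units; within the scatter). Compound 3 is expected at 12000 nM, within an estimated range of 6500 nM to 22000 nM.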

Compound 3, half-maximal inhibitory concentration: 11500 nM
Estimate against measurement, compound 3: 1.0-fold (0.02 log units) above; measured number inside the range.
By their numbers in this assay, from the lowest: compound 1; then compounds 3 and 2 (each within the scatter of the next).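

In this assay, going by these compounds alone, the halogen on the sulfonyl-bound aromatic ring is varied on its own for the first time, and the swap gives a 1.1-fold lower number from compound 2 to compound 3 (0.04 log units; within the scatter), so on this aromatic carbon, para to a large group, bromo and chloro cannot be told apart. The exchange on the ring amine nitrogen gives a 2.3-fold higher number from compound 1 to compound 3 (0.37 log units; beyond the scatter), a modest step in the same direction as a 2.6-fold higher number from compound 1 to compound 2 (0.41 log units; beyond the scatter), so the higher number holds with either halogen. No measured evidence accounts for either result.

The compounds shown leave open whether this sameness extends beyond these two halogens, to a fluoro, a methoxy or an amine on the same carbon. They also leave open where a methylsulfonyl or an acetyl on the ring amine nitrogen would fall relative to compound 1 and compound 3.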